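Amide-Type Side Chain in Place of a Sulfur-Bearing One

The source may report more compounds than this note shows. Statements on the series, on what has been measured and on what is new or still open speak of the compounds shown alone.

Measured so far:
compound 1, `C/N=C(/S)C1=CC(C)(C(F)(F)F)Oc2ccc([N+](=O)[O-])cc21`: 62.5%
compound 2, `C/N=C(/S)C1=CC(C(F)(F)F)(C(F)(F)F)Oc2ccc([N+](=O)[O-])cc21`: 68%

In a functional assay on the whole organism (aorta) with Rattus norvegicus as the target (a lower number here means a smaller maximal response, a higher number a larger maximal response), compound 2 gives 68%, and compound 1 gives 62.5%; the step of a number 5.5 percentage points higher from compound 1 to compound 2 (within the scatter) lies within the scatter, so the two numbers cannot be ranked. Compound 3, `N#CCCNC(=O)C1=CC(C(F)(F)F)(C(F)(F)F)Oc2ccc([N+](=O)[O-])cc21`, differs from compound 2 in one place: a group of 7 heavy atoms (4 carbon, 2 nitrogen, 1 oxygen; no ring) in place of a group of 4 heavy atoms (2 carbon, 1 nitrogen, 1 sulfur; no ring), on a double-bonded ring carbon. Among the compounds with values here, the only measured step, a number 5.5 percentage points higher from compound 1 to compound 2 (within the scatter), concerns the ring atom that bears two trifluoromethyl groups and not the group on the double-bonded ring carbon, so no measured step bears on this change. The data give no basis for a direction, and a shift in either sense is possible. Compound 3 is therefore expected to give 58% in this assay, with a wide range from 25% to 90%, which means an expected step of a number 10 percentage points lower from compound 2 to compound 3 (within the scatter).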

Compound 3, intrinsic activity: the largest response reached, in percent of the reference agonist's: 64.1%
The estimate for compound 3 lay 6.1 percentage points below the measured number, within the range that was stated.
By their numbers in this assay, from the lowest: compounds 1, 3 and 2 (each within the scatter of the next).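

In this assay, the change on the double-bonded ring carbon gives a number 3.9 percentage points lower from compound 2 to compound 3 (within the scatter). Within the data shown here, the earlier pair differed only at the saturated ring carbon, so this is the first reading at this position: the (2-cyanoethyl)carbamoyl group, which carries no sulfur, can take the place of the sulfur-bearing group with no readable difference in maximal response. Nothing at hand explains why the two groups give numbers this close.

Still open, as far as these compounds go, is whether the maximal response stays at this level with a carboxylic acid, a simple amine or a longer chain on that carbon. Also open, from the compounds shown here alone, is whether the (2-cyanoethyl)carbamoyl group gives the same reading when the saturated ring carbon bears one methyl and one trifluoromethyl group, as in compound 1.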